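The source may hold more compounds than are shown below. What is called first, only, known or untested is meant among the compounds shown, and "the series" means these compounds.

Notes on the series. In an ADME assay on cells (Peritoneal macrophage cell, Mus musculus) for cytotoxicity, read by fluorescence and resazurin assay, with a stated time of 3 days (on this read-out higher numbers stand for lower toxicity in this test and lower numbers for higher toxicity in this test), compound 1 `O=C(Nc1cc(-c2ccccn2)n[nH]1)N1CCC(c2cccc(F)c2)CC1` gives > 45000 nM as a limit and not a number. Compound 2 `N#Cc1ccc(C2CCN(C(=O)Nc3cc(-c4ccccn4)n[nH]3)CC2)cc1` stands at > 64000 nM which is also a limit, like the other two values shown. Compound 3 `O=C(Nc1cc(-c2ccccn2)n[nH]1)N1CCN(c2ccc(F)cc2)CC1` gives > 57000 nM as a limit as well. Compound 4 `O=C(Nc1cc(-c2ccccn2)n[nH]1)N1CCC(c2ccc(F)cc2)CC1` differs from compound 2 at one place, with fluoro in place of cyano on an aromatic carbon in words fluoro in place of cyano on an aromatic carbon. Among the compounds with values here, the one measured step that bears on this is a step that the two limits leave unreadable from compound 1 to compound 2 and it offers no size to carry over, with 4-cyanophenyl in place of 3-fluorophenyl on a saturated ring carbon. On that thin basis no step beyond the usual scatter is expected in this assay and no direction can be given. The expected step is an at least 1.1-fold lower number from compound 2 to compound 4 (0.06 log units; that floor lies within the scatter) and this is an estimate only. For compound 4 the estimate is 55000 nM with an expected range from 28000 nM to 100000 nM and a report as a limit is the likeliest outcome.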

Compound 4, half-maximal cytotoxic concentration: > 64000 nM
Compound 4 gave a limit, no number; the forecaster's own chance of this, stated with the estimate: 85%; middle value at least 1.1-fold (0.06 log units) from the limit.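

Within the data shown here, compound 1, compound 2 and compound 4 all stand as limits and not numbers, and no step among them can be read in this assay here. The compounds shown leave open whether cyano, fluoro or the place of the fluoro changes the read-out in this assay at all.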